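From dichlorophenyl to bromophenyl: a step in cytotoxicity

This account rests on a few compounds, and the source may have more. Where it says the series, first, only, none or still open, it means among the compounds named here.

Measured in an ADME assay on L02 cells (Homo sapiens) for cytotoxicity, read by MTT assay, with a stated time of 24 h; on this read-out lower numbers stand for stronger inhibition and higher numbers for weaker inhibition:
compound 1 `CN1C/C(=C\c2cccc([N+](=O)[O-])c2)C(=O)/C(=C/c2ccccc2F)C1` gives 13500 nM
compound 2 `CN1C/C(=C\c2cccc([N+](=O)[O-])c2)C(=O)/C(=C/c2ccc(Cl)c(Cl)c2)C1` gives 14800 nM

Only these two numbers exist so far, and compound 2 cannot be told apart from compound 1, since repeat measurements of one compound can differ this much. The next compound is compound 3 `CN1C/C(=C\c2cccc(Br)c2)C(=O)/C(=C/c2cccc([N+](=O)[O-])c2)C1`, which differs from compound 2 as follows: 3-bromophenyl in place of 3,4-dichlorophenyl on a double-bonded chain carbon bound to a double-bonded ring carbon. The swap sits on a double-bonded chain carbon bound to a double-bonded ring carbon.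

Among the measured compounds shown here, one measured step bears on this change, because it was made at the same kind of place: a 1.1-fold higher number from compound 1 to compound 2 (0.04 log units; within the scatter). There, 3,4-dichlorophenyl took the place of 2-fluorophenyl without moving the number beyond the scatter. On that evidence, no step beyond the scatter is expected in this assay, in either direction. A single step is thin support and shows no pattern, so the range stays wide.

For compound 3 the expected value is 14000 nM, with an estimated range from 7000 nM to 28000 nM. The estimated step is a 1.1-fold lower number from compound 2 to compound 3 (0.02 log units; within the scatter).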

Compound 3, half-maximal inhibitory concentration: 8070 nM
Beside the measured number, compound 3's estimate is 1.7-fold (0.24 log units) above it, within the range that was stated.
By their numbers in this assay, from the lowest: compounds 3, 1 and 2 (each within the scatter of the next).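

In this assay, the place on a double-bonded chain carbon bound to a double-bonded ring carbon has now held three different halogen-bearing phenyl groups, and neither new step leaves the scatter: there is a 1.8-fold lower number from compound 2 to compound 3 (0.26 log units; within the scatter), and there is a 1.7-fold lower number from compound 1 to compound 3 (0.22 log units; within the scatter). The earlier compounds shown here offered one swap, which could have been a lone case, whereas these three compounds can no longer be told apart in this read-out, even with a single bromine on the ring in place of two chlorines or one fluorine. Nothing available explains why these swaps leave the number within the scatter.

All three groups at this place are phenyl rings carrying halogen, so the flat result describes that narrow family only and says nothing about other kinds of group. An amine or a carboxylic acid on the phenyl ring, or a longer chain at the same place, could still shift the number beyond the scatter, and the compounds shown cannot tell whether it would.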